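The source may report more compounds than this note shows. Statements on the series, on what has been measured and on what is new or still open speak of the compounds shown alone.

Compound 3 (`CC(=O)Nc1cc(C)n(Cc2cc(Cl)ccc2OCc2ccccc2)n1`) carries an acetamido group on the shared core. In a physicochemical assay for lipophilicity, at pH 7.4 (on this read-out higher numbers stand for higher lipophilicity and lower numbers for lower lipophilicity), compound 3 gives > 3.7, which is a limit of the assay and not a number. Compound 2 (`Cc1cc(C(=O)NCc2ccccn2)nn1Cc1cc(Cl)ccc1OCc1ccccc1`) gives > 3.7, which is likewise a limit. Among the compounds with values here, compound 1 (`Cc1cc(C(=O)Nc2cccc(F)c2)nn1Cc1cc(Cl)ccc1OCc1ccccc1`) gives 2.8, the only actual number among the three. Compound 3 thus sits at the limit of > 3.7 in this assay, at which 2 of the 3 values shown sit.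

Compound 4 (`Cc1cc(NC(=O)C2CCCC2)nn1Cc1cc(Cl)ccc1OCc1ccccc1`) has cyclopentyl in place of methyl on a carbonyl carbon, taking the acetamido group to (cyclopentylcarbonyl)amino: cyclopentyl in place of methyl on a carbonyl carbon. Within the data shown here, no measured step makes this exchange, so the measured steps bear on it only loosely. They show a number at least 0.90 log units higher from compound 1 to compound 3 (beyond the scatter) and a number at least 0.90 log units higher from compound 1 to compound 2 (beyond the scatter), both at a different kind of change. The remaining comparison, a step that the two limits leave unreadable from compound 2 to compound 3, offers no size to carry over.

The expectation therefore rests mainly on the structural change, in which only carbon enters. With compound 3 at the limit of > 3.7 in this assay, at which 2 of the 3 values shown sit, a modest rise is expected in this assay, and the reading may again be only a limit. The expected step is a step that the limit leaves unreadable from compound 3 to compound 4. For compound 4 the estimated value is 4.1, with an expected range from 3.5 to 4.7.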

Compound 4, distribution coefficient: 3.5
The estimate for compound 4 lay 0.60 log units above the measured number, and the stated range covers the measured number.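

In this assay, compound 3 stands at a limit of the assay and not at a number: the limit of > 3.7 in this assay, at which 2 of the 4 values shown sit.

With cyclopentyl in place of methyl on a carbonyl carbon, the series gains a second actual number at this position, and the exchange gives a number at least 0.20 log units lower from compound 3 to compound 4 (that floor lies within the scatter). The five carbons that enter therefore bring no rise on this read-out, and the comparison with the ((pyridin-2-yl)methyl)carbamoyl group gives the same kind of result, a number at least 0.20 log units lower from compound 2 to compound 4 (that floor lies within the scatter). Set against the (3-fluorophenyl)carbamoyl group, the (cyclopentylcarbonyl)amino group gives a number 0.70 log units higher from compound 1 to compound 4 (beyond the scatter), the first step from compound 1 whose size can be read in full.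

Going by these compounds, the true size of the drops to compound 4 from the two compounds at the limit remains unknown, since each step gives only a floor, and that floor lies within the usual scatter. The compounds shown also leave open how the reading would respond on the same carbonyl carbon to a cyclopropyl group, a phenyl group, a longer open chain or a chain ending in an amine.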